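The source may report more compounds than this note shows. Statements on the series, on what has been measured and on what is new or still open speak of the compounds shown alone.

Measured so far:
Compound 1, `Cc1cc(OCc2c(-c3c(Cl)cccc3Cl)noc2C(C)C)ncc1[N+](=O)[O-]`, 89 nM
Compound 2, `O=C(O)c1ccccc1OCc1ccc(OCc2c(-c3c(Cl)cccc3Cl)noc2C2CC2)nc1C(F)(F)F`, 434 nM

Both compounds were tested in an assay on isolated protein for agonist activity at Bile acid receptor (Homo sapiens), read by FRET; a lower number here means that less compound is needed, a higher number that more compound is needed for the effect. Compound 1 gives 89 nM, and compound 2 gives 434 nM. Among the measured compounds shown here, of the two numbers, that of compound 2 is the higher; its only neighbour is compound 1, and the gap between them lies beyond the usual scatter of repeated measurements.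

Compound 3, `CC(Oc1cccc(C(=O)O)c1)c1ccc(OCc2c(-c3c(Cl)cccc3Cl)noc2C2CC2)nc1C(F)(F)F`, has not yet been measured. It differs from compound 2 in one place: 1-(3-carboxyphenoxy)ethyl in place of (2-carboxyphenoxy)methyl on an aromatic carbon. The change is 1-(3-carboxyphenoxy)ethyl in place of (2-carboxyphenoxy)methyl on an aromatic carbon, ortho to a trifluoromethyl group and two atoms from the ring nitrogen, with the shared core otherwise unchanged.

For the measured compounds named here, no pair of measured compounds shows a step of this kind, so nothing here tells how much such an exchange moves the number in this assay. The expectation is therefore a step no larger than the scatter in either direction, written as a 1.1-fold lower number from compound 2 to compound 3 (0.04 log units; within the scatter). For compound 3 the estimated value in this assay is 400 nM, with a range from 150 nM to 1100 nM.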

Compound 3, half-maximal effective concentration: 155 nM
Compound 3: the middle estimate sits 2.6-fold (0.41 log units) above what was measured; the measured number falls inside the stated range.
By their numbers in this assay, from the lowest: compounds 1 and 3 (each within the scatter of the next); then compound 2.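

At the aromatic carbon ortho to a trifluoromethyl group and two atoms from the ring nitrogen, the only step among the compounds shown, in this assay, is a 2.8-fold lower number from compound 2 to compound 3 (0.45 log units; beyond the scatter), so the number responds modestly to the choice of group here. The exchange leaves the counted features of the group the same, with one six-membered aromatic ring of carbon only, one double bond outside aromatic rings, and equal numbers of hydrogen-bond donors and acceptors, yet the number still moves, so what matters lies in how the group is arranged or in its added carbon. The compounds shown offer no independent information on why the number moved.

The exchange alters two things at once, the place of the carboxyl on the phenoxy ring and the ethyl in place of the methyl link, and only a group such as (3-carboxyphenoxy)methyl or 1-(2-carboxyphenoxy)ethyl would separate them. From the compounds shown here alone, it also remains open how the number would respond at this position if an amide or a nitrile stood in place of the carboxylic acid.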